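The source may hold more compounds than are shown below. What is called first, only, known or untested is meant among the compounds shown, and "the series" means these compounds.

Compound 2 `O=C(O)c1ccc(C(=O)/C(=C\c2ccc(F)cc2[N+](=O)[O-])SCc2ccc(Br)cc2)cc1` was examined in a physicochemical assay for solubility (on this read-out lower numbers stand for lower solubility and higher numbers for higher solubility), and here compound 2 gives < 1000 ug/mL, which is a limit of the assay rather than a number. Compound 1 `O=C(O)c1ccc(C(=O)/C(=C\c2ccc(F)c([N+](=O)[O-])c2)SCc2ccc(Cl)cc2)cc1` gives < 1000 ug/mL in this assay, also a limit. Compound 3 `O=C(O)c1ccc(C(=O)/C(=C\c2ccc(Cl)c([N+](=O)[O-])c2)S(=O)(=O)Cc2ccc(Br)cc2)cc1` gives < 1000 ug/mL in this assay, again a limit. Compound 2 therefore stands where every measured compound stands, because of the limit of < 1000 ug/mL in this assay, at which 3 of the 3 values shown sit. Compound 4 `O=C(O)c1ccc(C(=O)/C(=C\c2cc([N+](=O)[O-])ccc2F)SCc2ccc(Br)cc2)cc1` has not yet been measured. It differs from compound 2 by 2-fluoro-5-nitrophenyl in place of 4-fluoro-2-nitrophenyl on a double-bonded chain carbon bound to a double-bonded chain carbon. Among the compounds with values here, with no measured step between any two compounds to lean on, the step is expected to be a step that the limit leaves unreadable from compound 2 to compound 4, no change beyond the scatter and in no particular direction. Compound 4 is accordingly estimated at 300 ug/mL, within a range from 50 ug/mL to 1000 ug/mL.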

Compound 4, solubility: < 1000 ug/mL
Compound 4 was reported as a limit (the forecaster's own chance of this, stated with the estimate: 85%); the middle value lies beyond the limit too.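

No step can be read from compound 2 to compound 4 in this assay, because both are reported only as a limit: the limit of < 1000 ug/mL in this assay, at which 4 of the 4 values shown sit.

The compounds shown leave open what actual number each would give, and whether 2-fluoro-5-nitrophenyl in place of 4-fluoro-2-nitrophenyl changes the read-out at all.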